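Hydroxy in place of amino: notes on the series

A few compounds are considered here, and "the series" means these few. Any claim that something is new, unique, unknown or untested is made for them only; others in the source may bear on it.

In a functional assay on HCT-116 cells (Homo sapiens) for inhibition, read by MTT assay, with a stated time of 48 h (on this read-out higher numbers stand for weaker inhibition and lower numbers for stronger inhibition), compound 1 (`COc1cc(-c2nccn3cc(-c4ccc(F)cc4)nc23)cc(OC)c1OC`) gives 263 nM and compound 2 (`COc1cc(-c2nccn3cc(-c4ccc(N)cc4)nc23)cc(OC)c1OC`) gives 158 nM on the same read-out, and these two values cannot be told apart. Among the compounds with values here, the one measured step (a 1.7-fold lower number from compound 1 to compound 2 (0.22 log units; within the scatter)) is amino in place of fluoro on an aromatic carbon, the same carbon that changes next. Compound 3 (`COc1cc(-c2nccn3cc(-c4ccc(O)cc4)nc23)cc(OC)c1OC`) carries hydroxy in place of amino on an aromatic carbon, para to a large group (hydroxy in place of amino on an aromatic carbon). Within the data shown here, with only that one step (a 1.7-fold lower number from compound 1 to compound 2 (0.22 log units; within the scatter)) to go on, no change beyond the scatter is expected in this assay for compound 3, though a single step is thin evidence. The estimated step (a 1.2-fold higher number from compound 2 to compound 3 (0.08 log units; within the scatter)) stays small. Compound 3 is expected at 190 nM in a range from 80 nM to 450 nM for now.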

Compound 3, half-maximal inhibitory concentration: 901 nM
Compound 3: the middle estimate sits 4.7-fold (0.68 log units) below what was measured; the whole stated range lies below it.
By their numbers in this assay, from the lowest: compounds 2 and 1 (each within the scatter of the next); then compound 3.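

The position para to a large group is not indifferent to what sits on it: in this assay, the change to hydroxy gives a 5.7-fold higher number from compound 2 to compound 3 (0.76 log units; beyond the scatter), although amino and hydroxy match in their counts of hydrogen-bond donors and acceptors. Hydroxy also separates from fluoro, with a 3.4-fold higher number from compound 1 to compound 3 (0.53 log units; beyond the scatter), whereas the earlier step between fluoro and amino, a 1.7-fold lower number from compound 1 to compound 2 (0.22 log units; within the scatter), showed no such separation, so among these three groups hydroxy alone stands apart. No measurement at hand accounts for this difference.

Going by these compounds, it remains open whether methoxy, which keeps the oxygen but lacks the hydroxy hydrogen, would track hydroxy or the other two groups. A carboxylic acid or an aminomethyl group on the same carbon would also test how far this sensitivity extends.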